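Aryl substituent swap on the shared core: cytotoxicity notes

The compounds below may be only part of what the source reports. "The series", "measured", "known", "first", "only" and "open" are said of these compounds alone.

Measured so far:
- compound 1 `Cn1c(-c2cccc(Cl)c2)cnc1NC(=O)c1ccc(F)cc1`: > 50000 nM
- compound 2 `COc1ccc2nc(NC(=O)c3ccc(F)cc3)n(C)c2c1`: > 100000 nM

Both measurements come from a toxicity assay on THP-1 cells (Homo sapiens) for inhibition; on this read-out lower numbers stand for higher toxicity in this test and higher numbers for lower toxicity in this test. For compound 1 the read-out is a limit of the assay and not a number, > 50000 nM. For compound 2 the read-out is likewise a limit, > 100000 nM. Among the measured compounds shown here, compound 1 therefore stands at a limit only, as does the one further value in hand, given by the limit of > 50000 nM in this assay, at which 1 of the 2 values shown sits, and (the limit of > 100000 nM in this assay, at which 1 of the 2 values shown sits). For the measured compounds named here, no step between measured compounds that differ in one place exists in this set, so no measured step size is available.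

Compound 3 `COc1cccc(-c2cnc(NC(=O)c3ccc(F)cc3)n2C)c1` is not yet measured. It differs from compound 1 by methoxy in place of chloro on an aromatic carbon, which read one bond further out is 3-chlorophenyl to 3-methoxyphenyl. Going by the values given here, with compound 1 at a limit and no measured step to lean on, the expected step in this assay from compound 1 to compound 3 is none beyond the scatter, that is a step that the limit leaves unreadable from compound 1 to compound 3. Compound 3 is expected to give 60000 nM, in the range 25000 nM to 150000 nM, most probably again reported as a limit in this assay.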

Compound 3, half-maximal cytotoxic concentration: > 100000 nM
Compound 3 ended at the assay's limit; the forecaster's own chance of this, stated with the estimate: 80%; middle value at least 1.6-fold (0.22 log units) from the limit.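

Among the compounds shown here, compound 1 and compound 3 both stand at limits of the assay in this assay, and no step between them can be read. Still open is whether methoxy in place of chloro on an aromatic carbon shifts the read-out at all, and at what concentration any of the compounds shown would reach a half-maximal cytotoxic effect.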